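A few compounds are considered here, and "the series" means these few. Any claim that something is new, unique, unknown or untested is made for them only; others in the source may bear on it.

Values in a functional assay on A20 cells (Mus musculus) for inhibition, with stated times of 1 h, 16 h and 24 h; on this read-out higher numbers stand for weaker inhibition and lower numbers for stronger inhibition:
- compound 1 `CN1CCN(C(=O)[C@@H]2C[C@H](S(=O)(=O)c3ccccc3)C[C@H]2C(=O)NC2(C#N)CC2)CC1`: 17 nM
- compound 2 `N#CCNC(=O)[C@@H]1CN(S(=O)(=O)c2ccccc2)C[C@H]1C(=O)N1CCOCC1`: 4240 nM
- compound 3 `N#CCNC(=O)[C@@H]1CN(S(=O)(=O)c2ccccc2Cl)C[C@H]1C(=O)N1CCOCC1`: 208 nM
- compound 4 `N#CCNC(=O)[C@@H]1CN(S(=O)(=O)c2ccccc2C(F)(F)F)C[C@H]1C(=O)N1CCOCC1`: not yet measured

Of the three numbers, compound 3 holds the second highest, with compound 1 lower and compound 2 higher, both gaps beyond the scatter. The next change is trifluoromethyl in place of chloro on an aromatic carbon, ortho to a large group: trifluoromethyl in place of chloro on an aromatic carbon. Among the measured compounds shown here, one measured step bears on it: a 20-fold lower number from compound 2 to compound 3 (1.31 log units; beyond the scatter), a large step on replacing hydrogen with chloro. For the measured compounds named here, no measured step compares chloro with trifluoromethyl. Compound 4 still carries a group other than hydrogen there, so the gain in a 20-fold lower number from compound 2 to compound 3 (1.31 log units; beyond the scatter) is expected to persist, with no step beyond the scatter in this assay. The expected change is a 1.4-fold lower number from compound 3 to compound 4 (0.14 log units; within the scatter). For compound 4 the estimated value is 150 nM, with an expected range of 50 nM to 500 nM.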

Compound 4, half-maximal inhibitory concentration: 118 nM
Compound 4: middle estimate off by 1.3-fold (0.10 log units), on the high side; the measured number falls inside the stated range.
By their numbers in this assay, from the lowest: compound 1; then compounds 4 and 3 (each within the scatter of the next); then compound 2.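

In this assay, the step of a 1.8-fold lower number from compound 3 to compound 4 (0.25 log units; within the scatter) leaves trifluoromethyl and chloro indistinguishable at this place, on an aromatic carbon ortho to a large group. The step of a 36-fold lower number from compound 2 to compound 4 (1.56 log units; beyond the scatter) shows that the gain over hydrogen is not confined to chloro but is shared by two different groups. No available evidence bears on why these two groups read alike.

Still open, from the compounds shown here alone, is whether a methoxy group or an amine at this place would keep the gain. Also open, going by these compounds, is whether chloro or trifluoromethyl would have any effect on the core of compound 1.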